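A few compounds are considered here, and "the series" means these few. Any claim that something is new, unique, unknown or untested is made for them only; others in the source may bear on it.

Compound 1, `CCCCCCNc1ccc([N+](=O)[O-])cc1S(=O)(=O)N(C)C`, gives 4.9% in an assay on HEK293 cells for inhibition of solute carrier family 12 member 2 (Homo sapiens), read by fluorescence, with a stated time of 30 min, tested at 100 uM; a lower number here means a weaker effect, a higher number a stronger effect of the compound at the concentration tested.
Compound 2, `CCCCCCNc1ccc(C(=O)O)cc1S(=O)(=O)N(C)C`, gives 19.8% in this assay.

Among the two compounds measured so far, compound 2 stands highest: the step of a number 14.9 percentage points higher from compound 1 to compound 2 (beyond the scatter), which comes from carboxy in place of nitro on an aromatic carbon, lies beyond the scatter. Compound 3, `COCCNc1ccc(C(=O)O)cc1S(=O)(=O)N(C)C`, keeps the carboxy of compound 2 and changes the chain instead: methoxy in place of butyl on a saturated chain carbon, two bonds along the chain from a nitrogen on an aromatic ring. No measured step touches the chain, so the only step shown, a number 14.9 percentage points higher from compound 1 to compound 2 (beyond the scatter), concerns a different part of the molecule and gives no direct guide to this change. With nothing in the measured pairs to point one way or the other, compound 3 is expected to stay close to compound 2. For compound 3 the expected step is a number 4.8 percentage points lower from compound 2 to compound 3 (within the scatter), within the scatter. Compound 3 is therefore estimated at 15%, with a range from 2% to 30%.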

Compound 3, a percentage reported as inhibition, at one concentration (the size of the read-out at that concentration, not a potency): 4.1%
Beside the measured number, compound 3's estimate is 10.9 percentage points above it; the measured number falls inside the stated range.
By their numbers in this assay, from the lowest: compounds 3 and 1 (each within the scatter of the next); then compound 2.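

Read with the carboxy held constant, this is the first measured change to the chain, and it is not a neutral one: methoxy in place of butyl gives a number 15.7 percentage points lower from compound 2 to compound 3 (beyond the scatter) in this assay at this position, on a saturated chain carbon, two bonds along the chain from a nitrogen on an aromatic ring. The hexyl chain of compound 2 therefore counts towards its read-out, and the carboxy alone does not carry it. Nothing measured here explains the drop.

The change shortens the group and brings in an oxygen at once, and this single pair cannot separate those two differences. An all-carbon chain of the same length as the 2-methoxyethyl, a longer chain such as octyl, or an amine at the chain end would each address a part of that question.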